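A few compounds are considered here, and "the series" means these few. Any claim that something is new, unique, unknown or untested is made for them only; others in the source may bear on it.

Compound 1 `CCNC(=O)C1=C(C)NC(=O)NC1c1ccco1`: 1%
Compound 2 `CC1=C(C(=O)SC(C)C)C(c2ccco2)NC(=O)N1`: 22%
Compound 3 `CCC(CC)OC(=O)C1=C(C)NC(=O)NC1c1ccco1`: 35%

In an assay on membranes from HEK293 cells for displacement of a labelled ligand from adenosine receptor A2b (Homo sapiens), read by scintillation counting, with a stated time of 30 min, tested at 1 uM (a higher number here means more inhibition at the concentration tested (going by the name of the read-out), a lower number less inhibition), compound 3 stands highest of the three measured compounds: a number 13 percentage points higher from compound 2 to compound 3 (beyond the scatter) and a number 34 percentage points higher from compound 1 to compound 3 (beyond the scatter). Compound 4 `CC1=C(C(=O)OC2CCCCC2)C(c2ccco2)NC(=O)N1` differs from compound 3 by cyclohexyl in place of pentan-3-yl on an oxygen next to a carbonyl group. Within the data shown here, no measured step alters only this part of the ester; the steps that bear on it are those that exchanged the group on the carbonyl carbon, a number 21 percentage points higher from compound 1 to compound 2 (beyond the scatter) and a number 13 percentage points higher from compound 2 to compound 3 (beyond the scatter), which showed a gain each time a larger alkyl ester replaced the earlier group. The new change keeps an oxygen-linked saturated carbon group in place, so compound 4 is expected to move only slightly, a number 5 percentage points higher from compound 3 to compound 4 (within the scatter), a step within or barely beyond the scatter. Compound 4 is therefore estimated at 40%, with a range from 22% to 58%.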

Compound 4, a percentage reported as inhibition, at one concentration (the size of the read-out at that concentration, not a potency): 1%
For compound 4 the middle estimate is 39 percentage points above the measured one, outside the stated range (below it).
By their numbers in this assay, from the lowest: compounds 1 and 4 (each within the scatter of the next); then compound 2; then compound 3.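

In this assay the group on the ester oxygen proves decisive: cyclohexyl in place of pentan-3-yl gives a number 34 percentage points lower from compound 3 to compound 4 (beyond the scatter) and so removes the gain held by compound 3. The cyclohexyloxy group also trails isopropylsulfanyl, with a number 21 percentage points lower from compound 2 to compound 4 (beyond the scatter) as the step, while ethylamino offers no real contrast, with no change at the digits printed from compound 1 to compound 4 (within the scatter) as the step, so the ester link alone does not secure inhibition. Nothing available explains this loss. From the compounds shown here alone, it remains open how a cyclopentyl group or an open hexan-3-yl chain would read on this oxygen.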